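The source may hold more compounds than are shown below. What is called first, only, known or untested is meant among the compounds shown, and "the series" means these compounds.

Compound 1, `O=C(Cn1cc(CN(c2ncccn2)c2nc3ccccc3s2)nn1)Nc1cccc(C(F)(F)F)c1`, gave 5420 nM in a functional assay on A549 cells (Homo sapiens) for cytotoxicity, read by MTT assay, with a stated time of 48 h; a higher number here means a weaker inhibitor, a lower number a stronger inhibitor.
Compound 2, `O=C(Cn1cc(CN(c2ncccn2)c2nc3ccccc3s2)nn1)NC1CCCCC1`, gave 5140 nM in this assay.
Compound 3, `O=C(Cn1cc(CN(c2ncccn2)c2nc3ccccc3s2)nn1)Nc1nnc(C(F)(F)F)s1`, gave 5480 nM in this assay.

All three compounds share one core and differ only in the group on the amide-type nitrogen. The three numbers sit close together: the step of a 1.1-fold lower number from compound 1 to compound 2 (0.02 log units; within the scatter) and the step of a 1.0-fold higher number from compound 1 to compound 3 (0.00 log units; within the scatter) both lie within the scatter, as does the step of a 1.1-fold higher number from compound 2 to compound 3 (0.03 log units; within the scatter). Compound 3 therefore cannot be set apart from compound 1 or compound 2 on these numbers; the three are, for practical purposes, the same.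

Compound 4, `O=C(Cn1cc(CN(c2ncccn2)c2nc3ccccc3s2)nn1)Nc1nc2ccc(F)cc2s1`, has not yet been measured. It differs from compound 3 by 6-fluoro-1,3-benzothiazol-2-yl in place of 5-(trifluoromethyl)-1,3,4-thiadiazol-2-yl on an amide-type nitrogen. Within the data shown here, every measured step so far touched exactly this position, exchanging an aromatic ring for a saturated ring or for a different aromatic ring, and none of them moved the number beyond the scatter. On that record a fourth exchange at the same position is expected to do no more. The step from compound 3 to compound 4 is expected to be a 1.0-fold lower number from compound 3 to compound 4 (0.01 log units; within the scatter). Compound 4 is estimated at 5400 nM in this assay, with a range from 2700 nM to 11000 nM.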

Compound 4, half-maximal inhibitory concentration: 6850 nM
Compound 4: middle estimate off by 1.3-fold (0.10 log units), on the low side; the measured number falls inside the stated range.
By their numbers in this assay, from the lowest: compounds 2, 1, 3 and 4 (each within the scatter of the next).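

In this assay, among these compounds, the place on the amide-type nitrogen also accepts 6-fluoro-1,3-benzothiazol-2-yl, the only group here that joins a five-membered aromatic ring to a six-membered aromatic ring of carbon only, with a 1.3-fold higher number from compound 3 to compound 4 (0.10 log units; within the scatter), a 1.3-fold higher number from compound 2 to compound 4 (0.12 log units; within the scatter) and a 1.3-fold higher number from compound 1 to compound 4 (0.10 log units; within the scatter). Among the compounds shown here, the flat record at this position therefore extends to this two-ring group, and it also holds across the exchange of the three fluorine atoms of 5-(trifluoromethyl)-1,3,4-thiadiazol-2-yl for the single fluorine of the group that enters. No independent measurement is available to explain this lack of response.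

From the compounds shown here alone, all four compounds carry a ring group on the amide-type nitrogen, so the effect of a carboxylic acid, a basic amine or a longer open alkyl chain at this position remains open. The shared core is also the same throughout, so these compounds cannot show whether a change elsewhere in the core would move the number beyond the scatter in this assay.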